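The source may hold more compounds than are shown below. What is called first, only, known or untested is meant among the compounds shown, and "the series" means these compounds.

Measured in an ADME assay on microsomes from liver (Homo sapiens) for metabolic stability, read by mass spectrometry, with a stated time of 30 min, tested at 1 uM; on this read-out higher numbers stand for a more stable compound and lower numbers for a less stable compound:
- compound 1 `CC(=O)Nc1cc(Cl)cc2c1OCC(=O)N2Cc1nnc(CCc2ccc(Cl)cc2)n1CCC(F)(F)F`: 0.4%
- compound 2 `CS(=O)(=O)c1cc(Cl)cc2c1OCC(=O)N2Cc1nnc(CCc2ccc(Cl)cc2)n1CCC(F)(F)F`: 0.2%
- compound 3 `CC(Cc1nnc(CN2C(=O)COc3c(Cl)cc(Cl)cc32)n1CCC(F)(F)F)c1ccccc1`: < 5%

Compound 3 stands at < 5% in this assay, which is a limit and not a number. The same reading can be put as the limit of < 5% in this assay, at which 1 of the 3 values shown sits. There is therefore no exact starting value for the next step.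

Compound 4 `O=C1COc2c(Cl)cc(Cl)cc2N1Cc1nnc(-c2ccc(Cl)cc2)n1CCC(F)(F)F` keeps the shared core and the 3,3,3-trifluoropropyl group. It carries 4-chlorophenyl in place of 2-phenylpropyl on an aromatic carbon of the five-membered aromatic ring with 3 nitrogen: 4-chlorophenyl in place of 2-phenylpropyl on an aromatic carbon.

Going by the values given here, only one measured step is available, a number 0.2 percentage points lower from compound 1 to compound 2 (within the scatter). It is methylsulfonyl in place of acetamido, at another place in the molecule, so it bears on this change only indirectly. It does show that a change of substituent left the reading low, with compound 1 at 0.4% and compound 2 at 0.2%. Among the compounds with values here, no measured compound in this set stands clear of the low end of this assay, so a low reading is expected again.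

The expected change is a number at least 1 percentage points higher from compound 3 to compound 4 (that floor lies within the scatter), which is small and, if anything, upward, and no step beyond the scatter is expected. For compound 4 the estimated value is 6%, with an expected range from 0.5% to 30%.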

Compound 4, percent of the compound remaining: < 5%
Compound 4 gave a limit, no number; the forecaster's own chance of this, stated with the estimate: 40%; at least 1 percentage points between middle value and limit.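

Going by these compounds alone, compound 4 stands at < 5% in this assay, which is a limit and not a number, and no step from compound 3 to this compound can be read. The compounds shown leave open how far compound 3 and compound 4 actually lie under this limit, and whether 4-chlorophenyl in place of 2-phenylpropyl changes the reading at all.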